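Changing the group on the carbonyl carbon of compound 2

The source may hold more compounds than are shown below. What is called first, only, known or untested is meant among the compounds shown, and "the series" means these compounds.

Measured in a functional assay on the whole organism for inhibition, with Cavia porcellus as the target; a higher number here means that more compound is needed for the effect, a lower number that less compound is needed:
- compound 1 `COc1ccccc1OCC1SCCN1C(=O)CC(=O)O` gives 20 mg/kg
- compound 2 `COc1ccccc1OCC1SCCN1C(=O)CC(=O)N1CCN(C)CC1` gives 27 mg/kg

For the measured compounds named here, compound 2 (27 mg/kg) and compound 1 (20 mg/kg) lie within the scatter of each other, so compound 2 stands level with the only other number available. Compound 3 `COc1ccccc1OCC1SCCN1C(=O)CC(=O)NCc1ccccn1` carries ((pyridin-2-yl)methyl)amino in place of 4-methylpiperazin-1-yl on a carbonyl carbon. Going by the values given here, one measured step bears on this place: replacing hydroxy on that carbonyl carbon (a 1.4-fold higher number from compound 1 to compound 2 (0.13 log units; within the scatter)) stayed within the scatter. Among the compounds with values here, no measured compound carries the entering group, so this support is thin. No step beyond the scatter is expected in this assay and no direction can be named. The estimated step is small (a 1.1-fold lower number from compound 2 to compound 3 (0.03 log units; within the scatter)). For compound 3 the expected value is 25 mg/kg with an estimated range from 10 mg/kg to 60 mg/kg.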

Compound 3, dose for half-maximal effect: 26 mg/kg
The estimate for compound 3 lay 1.0-fold (0.02 log units) below the measured number, and the stated range covers the measured number.
By their numbers in this assay, from the lowest: compounds 1, 3 and 2 (each within the scatter of the next).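

In this assay the step to ((pyridin-2-yl)methyl)amino from 4-methylpiperazin-1-yl on the carbonyl carbon (a 1.0-fold lower number from compound 2 to compound 3 (0.02 log units; within the scatter)) and the step to the same group from hydroxy (a 1.3-fold higher number from compound 1 to compound 3 (0.11 log units; within the scatter)) both stay within the scatter. The earlier pair compared only hydroxy and 4-methylpiperazin-1-yl, whereas all three groups now stand level at this place, including one with a six-membered aromatic ring and one with a six-membered non-aromatic ring. No supporting measurement is available to explain this level reading.

From the compounds shown here alone, it remains open whether a simple methylamino group, a benzylamino group or a longer chain between the amide nitrogen and the pyridine ring would also stay level. The compounds also leave open whether a group such as a primary amine at this place would give a step beyond the scatter.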